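The compounds below may be only part of what the source reports. "The series", "measured", "known", "first", "only" and "open" are said of these compounds alone.

Going by the values given here, in a functional assay on CHO cells with adenosine receptor A1 (Homo sapiens) as the target, read by cAMP accumulation and immunoassay, with a stated time of 6 min, tested at 0.1 uM (on this read-out higher numbers stand for a weaker effect at the one concentration tested and lower numbers for a stronger effect), compound 3 `Nc1scc(CN2CCN(c3ccc([N+](=O)[O-])cc3)CC2)c1C(=O)c1ccc(Cl)cc1` gives -13%, the lowest of the three numbers measured so far. Compound 1 `CC(C)N1CCN(Cc2csc(N)c2C(=O)c2ccc(Cl)cc2)CC1` gives 3.6% and compound 2 `Nc1scc(CN2CCN(c3cccc(Cl)c3Cl)CC2)c1C(=O)c1ccc(Cl)cc1` gives 3.2%; these two lie within the scatter of each other, as a number 0.4 percentage points lower from compound 1 to compound 2 (within the scatter) shows. Compound 4 `Nc1scc(CN2CCN(c3ccncc3)CC2)c1C(=O)c1ccc(Cl)cc1` differs from compound 3 in one place: pyridin-4-yl in place of 4-nitrophenyl on an amine nitrogen in a ring. The measured steps that bear on this are the two that brought the 4-nitrophenyl in, a number 16.6 percentage points lower from compound 1 to compound 3 (beyond the scatter) and a number 16.2 percentage points lower from compound 2 to compound 3 (beyond the scatter), both modest. The one other aromatic ring tested on that nitrogen, 2,3-dichlorophenyl, gave a number within the scatter of the isopropyl, so a partial return toward those values is plausible but not assured. Compound 4 is therefore expected to give about -4%, within -18% to 10%. That means an expected step of a number 9 percentage points higher from compound 3 to compound 4 (within the scatter).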

Compound 4, a percentage reported as activity, at one concentration (the size of the read-out at that concentration, not a potency): 1.4%
Estimate against measurement, compound 4: 5.4 percentage points below, and the stated range covers the measured number.
By their numbers in this assay, from the lowest: compound 3; then compounds 4, 2 and 1 (each within the scatter of the next).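

In this assay, the change from 4-nitrophenyl to pyridin-4-yl gives a number 14.4 percentage points higher from compound 3 to compound 4 (beyond the scatter), so having a six-membered aromatic ring on this ring nitrogen is not enough to keep the low number of compound 3. Going by these compounds alone, the other two steps, a number 1.8 percentage points lower from compound 2 to compound 4 (within the scatter) and a number 2.2 percentage points lower from compound 1 to compound 4 (within the scatter), leave the 4-nitrophenyl as the only one of these four groups set apart from the rest. Nothing available here explains why this group stands apart. Going by these compounds, it remains open whether a phenyl ring carrying a nitrile or a carboxylic acid in place of the nitro group would behave like compound 3 or like compound 4.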